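A few compounds are considered here, and "the series" means these few. Any claim that something is new, unique, unknown or untested is made for them only; others in the source may bear on it.

Three compounds built on one shared core have been examined in an ADME assay on MOLT-3 cells (Homo sapiens) for cytotoxicity, with a stated time of 7 days; on this read-out lower numbers stand for higher toxicity in this test and higher numbers for lower toxicity in this test. Compound 1 `Nc1nc(NC2CC2)c2ncn(/C=C3/CC3(CO)CO)c2n1` carries a cyclopropylamino group on the core. In this assay compound 1 gives > 20000 nM, and this is a limit of the assay rather than a number. Compound 2 `CCCNc1nc(N)nc2c1ncn2/C=C1/CC1(CO)CO` carries a propylamino group instead, and in this assay compound 2 gives "not determined" (no result reported). Compound 3 `CC(C)CNc1nc(N)nc2c1ncn2/C=C1/CC1(CO)CO` carries an isobutylamino group, and in this assay compound 3 gives "not determined" (no result reported). Among the three entries, then, only one carries any reading at all, and that reading is the limit of > 20000 nM in this assay, at which 1 of the 3 values shown sits; compound 1 stands alone there, with no number of its own and no neighbour to compare against.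

Compound 4 `CCCCCOc1nc(N)nc2c1ncn2/C=C1/CC1(CO)CO` is the next member. It differs from compound 1 in a single place: pentyloxy in place of cyclopropylamino on an aromatic carbon

For the measured compounds named here, no pair of measured compounds here differs in one place, so no measured step exists from which the effect of this change could be read. Going by the values given here, with the one limit for compound 1 as the only anchor, the step of a number no higher from compound 1 to compound 4 (the limit leaves the size open) is expected to stay within the scatter of repeated measurements. Compound 4 is accordingly expected to give about 20000 nM, within a range from 5000 nM to 80000 nM, and most probably once more only as a limit.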

Compound 4, half-maximal cytotoxic concentration: > 20000 nM
Compound 4: a limit, no number; the forecaster's own chance of this, stated with the estimate: 75%; the middle value sits exactly at the limit.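

Compound 1 and compound 4 both give only a limit of the assay in this assay, not a number, so no step between them can be read: the limit of > 20000 nM in this assay, at which 2 of the 4 values shown sit.

The compounds shown leave open how far pentyloxy and cyclopropylamino on the shared core differ in this assay, and at what concentration, if any, either compound becomes toxic to these cells.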